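Ester to hydroxymethyl on the shared core

The source may report more compounds than this note shows. Statements on the series, on what has been measured and on what is new or still open speak of the compounds shown alone.

Values in a functional assay on cells (Platelet, Homo sapiens) for inhibition (on this read-out lower numbers stand for stronger inhibition and higher numbers for weaker inhibition), each one a limit of the assay:
- compound 1 `CCOC(=O)c1ccc(-c2nn(Cc3cccc(F)c3)c3ccccc23)cc1`: > 10000 nM
- compound 2 `CCOC(=O)c1ccc(-c2nn(Cc3ccc(OC)cc3)c3ccccc23)cc1`: > 10000 nM
- compound 3 `CCCOC(=O)c1ccc(-c2nn(Cc3ccccc3)c3ccccc23)cc1`: > 10000 nM

Compound 3 gives > 10000 nM, which is a limit and not a number. For the measured compounds named here, the series so far offers only (the limit of > 10000 nM in this assay, at which 3 of the 3 values shown sit). The move to compound 4 `OCc1ccc(-c2nn(Cc3ccccc3)c3ccccc23)cc1` is hydroxymethyl in place of propoxycarbonyl on an aromatic carbon. Going by the values given here, the only measured step is a step that the two limits leave unreadable from compound 1 to compound 2, at another place, so it gives no size to carry over. Among the compounds with values here, no measured compound carries hydroxymethyl, and the expectation rests on the structural change alone. A modest step toward stronger inhibition is expected, with a further limit still possible. The estimated step is an at least 2.0-fold lower number from compound 3 to compound 4 (0.30 log units; that floor lies within the scatter). For compound 4 the expected value is 5000 nM. The estimated range for compound 4 runs from 1500 nM to 20000 nM.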

Compound 4, half-maximal inhibitory concentration: > 10000 nM
Compound 4: a limit, no number (the forecaster's own chance of this, stated with the estimate: 45%); middle value at least 2.0-fold (0.30 log units) from the limit.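

For the compounds shown here, compound 4 gives > 10000 nM as a limit and not a number, so no step from compound 3 to compound 4 can be read. How strongly any of these compounds inhibits stays open, since all share one limit: the limit of > 10000 nM in this assay, at which 4 of the 4 values shown sit.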